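A Pyridine for a Fluorophenyl: Estimating Compound 3

This account rests on a few compounds, and the source may have more. Where it says the series, first, only, none or still open, it means among the compounds named here.

Compound 1 `CN(C)CCCCCCN(C)C1=Nc2ccccc2C(CC(=O)NCc2ccccc2)N1c1ccc(-c2ccccc2)cc1`: 1190 nM
Compound 2 `CN(C)CCN1CCN(C2=Nc3ccccc3C(CC(=O)NCc3ccc(F)cc3)N2c2ccc(-c3ccccc3)cc2)CC1`: 1600 nM

In a functional assay on A2780 cells (Homo sapiens) for cytotoxicity, read by MTT assay, with a stated time of 48 h (a lower number here means a stronger inhibitor, a higher number a weaker inhibitor), compound 1 gives 1190 nM, and compound 2 gives 1600 nM. Compound 2 has the higher of the two numbers, but its gap to compound 1 lies within the scatter of repeated measurements, so the two compounds cannot be separated on these data.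

Compound 3 `CN(C)CCN1CCN(C2=Nc3ccccc3C(CC(=O)NCc3ccccn3)N2c2ccc(-c3ccccc3)cc2)CC1` is compound 2 with a single change: pyridin-2-yl in place of 4-fluorophenyl on a saturated chain carbon bound to an amide-type nitrogen. Among the compounds with values here, no two measured compounds differ only in this way, so nothing measured shows how large a step such a swap brings. Within the data shown here, the only comparison available, compound 1 against compound 2, involves several changes at once and still shows a gap within the scatter. One aromatic ring is exchanged for another at the same place, and the expected step is a 1.3-fold higher number from compound 2 to compound 3 (0.10 log units; within the scatter), small and without a clear direction, most likely not beyond the scatter.

Compound 3 is therefore estimated at 2000 nM, expected to fall between 800 nM and 5000 nM.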

Compound 3, half-maximal inhibitory concentration: 4860 nM
The estimate for compound 3 lay 2.4-fold (0.39 log units) below the measured number; the measured number falls inside the stated range.
By their numbers in this assay, from the lowest: compounds 1 and 2 (each within the scatter of the next); then compound 3.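

Placing pyridin-2-yl where 4-fluorophenyl stood, on a saturated chain carbon bound to an amide-type nitrogen, gives a 3.0-fold higher number from compound 2 to compound 3 (0.48 log units; beyond the scatter) in this assay. This shows that the aromatic ring at this place can matter, which the earlier pair could not show, as compound 1 and compound 2 differ in several places at once and sit within the scatter of each other. The swap removes the fluorine and brings a ring nitrogen with one hydrogen-bond acceptor, yet nothing available explains why the number rises, and no outside measurement bears on this step.

Within the data shown here, the single step cannot say whether losing the fluorine, gaining the ring nitrogen, or both together accounts for the rise. A plain phenyl ring on the frame of compound 2 would separate those two parts, and a thienyl ring would show how another ring with a hetero atom fares; compound 1 does carry a plain phenyl there, but its other differences keep it from answering the question.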